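Replacing phenyl on the carbonyl carbon of compound 1

The source may report more compounds than this note shows. Statements on the series, on what has been measured and on what is new or still open speak of the compounds shown alone.

Compound 1 `O=C(/C=C/C=C/c1ccccc1)c1ccccc1`: 44300 nM
Compound 2 `O=C(/C=C/C=C/c1ccccc1)c1ccc(Cl)cc1`: "not determined" (no result reported)

In an ADME assay on RAW264.7 cells (Mus musculus) for cytotoxicity, read by MTT assay (a higher number here means a weaker inhibitor, a lower number a stronger inhibitor), compound 1 gives 44300 nM. Within the data shown here, this is the only number, so compound 1 cannot yet be ranked, and compound 2 offers no comparison without a result.

Compound 3 `Cc1ccc(C(=O)/C=C/C=C/c2ccccc2)s1` departs from compound 1 in one place: 5-methylthiophen-2-yl in place of phenyl on a carbonyl carbon. It has 5-methylthiophen-2-yl in place of phenyl on a carbonyl carbon.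

Among the measured compounds shown here, no step between measured compounds is available to calibrate this change, so the expectation rests on compound 1 at 44300 nM alone. No step beyond the scatter is expected in this assay, and no direction can be favoured.

The estimated step is a 1.1-fold lower number from compound 1 to compound 3 (0.04 log units; within the scatter). For compound 3 the expected value is 40000 nM, within an estimated range of 15000 nM to 100000 nM.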

Compound 3, half-maximal inhibitory concentration: > 100000 nM
Compound 3: only a limit was reported; the forecaster's own chance of this, stated with the estimate: 15%; at least 2.5-fold (0.39 log units) between middle value and limit.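

In this assay, among these compounds, the position on the carbonyl carbon proves sensitive to the change: 5-methylthiophen-2-yl in place of phenyl gives an at least 2.2-fold higher number from compound 1 to compound 3 (0.35 log units; beyond the scatter), the first step that can be read. Compound 3 gives > 100000 nM, which is a limit and not a number. The step therefore fixes a direction and a minimum size, while its full size stays unknown: the limit of > 100000 nM in this assay, at which 1 of the 3 values shown sits.

The compounds shown leave open whether the step follows from the five-membered ring with its sulfur or from the methyl, a separation that plain thiophen-2-yl on the same carbonyl carbon would provide. Among the compounds shown here, also open is how an amine on the phenyl of compound 1 would read in this assay, and no step to compound 2 can be read.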